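The source may report more compounds than this note shows. Statements on the series, on what has been measured and on what is new or still open speak of the compounds shown alone.

Compound 1 `COc1ccc(/C=C2\S/C(=N\c3csc(-c4ccc(Cl)cc4)c3)NC2=O)cc1` and compound 2 `COc1ccc(/C=C2\S/C(=N\c3csc(-c4ccc(Cl)cc4)c3)NC2=O)cc1OC` share one core, while compound 3 `COc1cccc(N2C(=O)CS/C2=N\c2csc(-c3ccc(Cl)cc3)c2)c1` and compound 4 `COc1ccc(N2C(=O)CS/C2=N\c2csc(-c3ccc(Cl)cc3)c2)cc1OC` share another; the difference between the two cores is not broken down here. The compounds are compared in a functional assay on MDA-MB-231 cells (Homo sapiens) for cytotoxicity, read by MTT assay, with a stated time of 72 h; a lower number here means a stronger inhibitor, a higher number a weaker inhibitor. In this assay compound 1 gives 1200 nM. Compound 2, in the same assay, gives 1900 nM. The change between them is methoxy in place of hydrogen on an aromatic carbon, and it produced a 1.6-fold higher number from compound 1 to compound 2 (0.20 log units; within the scatter). For compound 3 this assay reports only a limit, > 50000 nM, which is the limit described in the limit of > 50000 nM in this assay, at which 1 of the 3 values shown sits.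

Compound 4 has not yet been measured. It differs from compound 3 by methoxy in place of hydrogen on an aromatic carbon. This is the same kind of change as from compound 1 to compound 2, but not the same: in compound 2 the entering methoxy sits meta to a large group, whereas in compound 4 it sits para to a large group.

Because the step of a 1.6-fold higher number from compound 1 to compound 2 (0.20 log units; within the scatter) was within the scatter, the same kind of change on the core of compound 3 is expected to leave the number where it was, at or past the limit. Compound 4 is therefore expected to give about 60000 nM, with a plausible spread from 20000 nM to 200000 nM. The step this expectation means is estimated as a step that the limit leaves unreadable from compound 3 to compound 4, most likely reported again as a limit rather than a number.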

Compound 4, half-maximal inhibitory concentration: 46900 nM
Compound 4: the middle estimate sits 1.3-fold (0.11 log units) above what was measured, within the range that was stated.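

In this assay compound 3 has only a limit, > 50000 nM, and not a number, so the effect of the added methoxy on its core can be stated only as a floor. Methoxy in place of hydrogen on an aromatic carbon gives an at least 1.0-fold lower number from compound 3 to compound 4 (0.02 log units; that floor lies within the scatter), and set beside the same change on the core of compound 1, the comparison stands as follows: the same change on two cores in this assay, a 1.6-fold higher number (0.20 log units; within the scatter) from compound 1 to compound 2 and an at least 1.0-fold lower number (0.02 log units; that floor lies within the scatter) from compound 3 to compound 4; the limit leaves it open whether they differ. Going by these compounds, neither step shows this change moving the number beyond the scatter, but that does not prove the change carries over equally from one core to the other: the true number for compound 3 is unknown, and the real step on its core could be much larger than the floor.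

The compounds shown leave open what a different group would do at this place on either core, for example an amine or a carboxylic acid in place of the methoxy. Also open, on these data alone, is how this change behaves on a compound of the second core that starts from a measured number rather than a limit, which would allow the steps on the two cores to be compared directly.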